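Compound 3 to compound 4: fluoro for bromo

This account rests on a few compounds, and the source may have more. Where it says the series, first, only, none or still open, it means among the compounds named here.

In a physicochemical assay for solubility, in phosphate buffer, measured as kinetic solubility, at pH 7.4 (on this read-out lower numbers stand for lower solubility and higher numbers for higher solubility), compound 1 `Cc1ccc(C)c(-c2nc(CN3CCC(C(=O)NCCCN4C[C@H](C)C[C@H](C)C4)CC3)c(C)o2)c1` gives 56.1 ug/mL as a measured number. Compound 2 `Cc1oc(-c2ccc(Cl)cc2)nc1CN1CCC(C(=O)NCCCN2C[C@H](C)C[C@H](C)C2)CC1` gives > 72 ug/mL as a limit. Compound 3 `COc1cccc(Br)c1-c1nc(CN2CCC(C(=O)NCCCN3C[C@H](C)C[C@H](C)C3)CC2)c(C)o1` gives > 83 ug/mL as a limit too, so it stands without an exact number. Compound 4 `COc1cccc(F)c1-c1nc(CN2CCC(C(=O)NCCCN3C[C@H](C)C[C@H](C)C3)CC2)c(C)o1` carries fluoro in place of bromo on an aromatic carbon ortho to a large group. The measured steps of an at least 1.4-fold higher number from compound 1 to compound 3 (0.17 log units; that floor lies within the scatter) and an at least 1.2-fold higher number from compound 1 to compound 2 (0.10 log units; that floor lies within the scatter) both change the substituted phenyl group, and both floors lie within the scatter. In this assay the expected at least 1.1-fold lower number from compound 3 to compound 4 (0.04 log units; that floor lies within the scatter) is no step beyond the scatter. Compound 4 is expected at 75 ug/mL with 45 ug/mL to 100 ug/mL as the estimated range.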

Compound 4, solubility: > 74 ug/mL
Compound 4 ended at the assay's limit; the forecaster's own chance of this, stated with the estimate: 60%; the middle value lies beyond the limit too.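

In this assay compound 4 gives > 74 ug/mL, which is a limit and not a number. With fluoro as with bromo on this carbon, the 2-halo-6-methoxyphenyl compounds end at a limit, so this change gives no exact reading. For the compounds shown here, the one readable step is an at least 1.3-fold higher number from compound 1 to compound 4 (0.12 log units; that floor lies within the scatter), and the steps from compound 2 and compound 3 to compound 4 cannot be read, having limits at both ends.

From the compounds shown here alone, the size of the fluoro for bromo change stays open. So does whether an amine or a carboxylic acid on this carbon would also end at a limit.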